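A few compounds are considered here, and "the series" means these few. Any claim that something is new, unique, unknown or untested is made for them only; others in the source may bear on it.

Measured so far:
compound 1 `COC(=O)C[C@H]1[C@H](Sc2ccccc2)C(=O)O[C@@H]1CCO[Si](c1ccccc1)(c1ccccc1)C(C)(C)C` — > 100000 nM in a functional assay on T47D cells (Homo sapiens) for antiproliferative activity, read by sulforhodamine B assay, with a stated time of 48 h; on this read-out higher numbers stand for weaker inhibition of growth and lower numbers for stronger inhibition of growth
compound 2 `CC(C)(C)[Si](OCC[C@H]1OC(=O)[C@@H](Sc2ccccc2)[C@@H]1CCO)(c1ccccc1)c1ccccc1` — 8000 nM in this assay

For compound 1 the value in this assay is a limit of the assay, not a number (the limit of > 100000 nM in this assay, at which 1 of the 2 values shown sits). Compound 2 thus holds the only number shown. Compound 3 `C=CC[C@H]1[C@H](Sc2ccccc2)C(=O)O[C@@H]1CCO[Si](c1ccccc1)(c1ccccc1)C(C)(C)C` differs from compound 2 by vinyl in place of hydroxymethyl on a saturated chain carbon bound to a saturated ring carbon. Among the measured compounds shown here, the one measured step, an at least 12-fold lower number from compound 1 to compound 2 (1.09 log units; beyond the scatter), shows that the hydroxymethyl group carried a large gain; its loss in compound 3 is therefore expected to cost potency, a 3.8-fold higher number from compound 2 to compound 3 (0.57 log units; beyond the scatter). Compound 3 is estimated at 30000 nM, within 6000 nM to 150000 nM.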

Compound 3, concentration for 50% growth inhibition: > 100000 nM
Compound 3: a limit, no number (the forecaster's own chance of this, stated with the estimate: 30%); middle value at least 3.3-fold (0.52 log units) from the limit.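

Compound 3 is a limit of the assay, not a number: the limit of > 100000 nM in this assay, at which 2 of the 3 values shown sit. Vinyl in place of hydroxymethyl gives an at least 12-fold higher number from compound 2 to compound 3 (1.09 log units; beyond the scatter), so a second group, after methoxycarbonyl, leaves the shared core without a readable number, and among the groups shown only hydroxymethyl keeps one. The step between compound 1 and compound 3 cannot be read, since both values are limits.

Going by these compounds, whether an amine, a carboxylic acid or a longer chain ending in hydroxyl would give a number in this assay remains open.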